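The source may report more compounds than this note shows. Statements on the series, on what has been measured and on what is new or still open speak of the compounds shown alone.

Measured so far in a functional assay on HCT-15 cells (Homo sapiens) for cytotoxicity, read by sulforhodamine B assay; on this read-out lower numbers stand for stronger inhibition and higher numbers for weaker inhibition:
- compound 1 `COC(=O)CNc1nc(-c2ccccc2)nc2ccccc12`: 37.5 ug/mL
- compound 2 `c1ccc(-c2nc(NC3CCCCC3)c3ccccc3n2)cc1`: 2.76 ug/mL
- compound 3 `CNc1nc(-c2ccccc2)nc2ccccc12`: 21.2 ug/mL

Compound 1 and compound 3 sit together at the high, weaker end of these numbers, and compound 2 lies clearly below both.

The next compound, compound 4 `CN(C)CCN(C)c1nc(-c2ccccc2)nc2ccccc12`, keeps the core of compound 1 but exchanges the group on an aromatic carbon: (2-(dimethylamino)ethyl)(methyl)amino in place of ((methoxycarbonyl)methyl)amino on an aromatic carbon. Within the data shown here, no measured compound carries a chain like the entering one, so the evidence is only indirect.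

Three measured steps change the group at this same place. Losing the methoxycarbonyl gives a 1.8-fold lower number from compound 1 to compound 3 (0.25 log units; within the scatter), which is no clear change. Bringing in cyclohexyl gives a 14-fold lower number from compound 1 to compound 2 (1.13 log units; beyond the scatter), so this substituent can move the number a long way. The reverse kind of exchange, a 7.7-fold higher number from compound 2 to compound 3 (0.89 log units; beyond the scatter), shows that a small methyl does not keep that gain. The entering chain has no ring, unlike the cyclohexyl of compound 2, so a step of that full size is not assumed.

Expected in this assay is a moderately lower number, an estimated 3.8-fold lower number from compound 1 to compound 4 (0.57 log units; beyond the scatter). For compound 4 the estimated value is 10 ug/mL, with an expected range from 2.5 ug/mL to 35 ug/mL.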

Compound 4, half-maximal inhibitory concentration: 26.5 ug/mL
Beside the measured number, compound 4's estimate is 2.7-fold (0.42 log units) below it; low and high end bracket the measured number.
By their numbers in this assay, from the lowest: compound 2; then compounds 3, 4 and 1 (each within the scatter of the next).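

In this assay, the exchange at this aromatic carbon gives a 1.4-fold lower number from compound 1 to compound 4 (0.15 log units; within the scatter) and adding the 2-(dimethylamino)ethyl chain to the nitrogen gives a 1.3-fold higher number from compound 3 to compound 4 (0.10 log units; within the scatter) so neither change clearly moves the number, even though the entering group has no hydrogen-bond donor and no carbonyl. A ring-free chain with more heavy atoms than the leaving group therefore does not reproduce the low number of compound 2, and replacing cyclohexylamino with the new group gives a 9.6-fold higher number from compound 2 to compound 4 (0.98 log units; beyond the scatter) which leaves compound 2 clearly apart from compounds 1, 3 and 4, while those three remain within the scatter of their neighbours in the order. Nothing measured here explains why cyclohexylamino stands apart from the ring-free groups.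

The compounds shown cannot separate the effect of the ring itself from that of the carbon content of cyclohexyl, which a straight hexyl chain or a smaller cyclopentyl ring on the same nitrogen would help to test. They also leave open what the terminal dimethylamino contributes, since a plain pentyl chain or a terminal hydroxyl on the same chain would have to be compared with compound 4 to show this.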